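The compounds below may be only part of what the source reports. "The series", "measured", "known", "first", "only" and "open" are said of these compounds alone.

Compounds measured in a functional assay for inhibition of sodium/hydrogen exchanger (Oryctolagus cuniculus); a higher number here means a weaker inhibitor, a lower number a stronger inhibitor:
- compound 1, `Cc1cc(-c2cc(Cl)cc(Cl)c2)c(S(C)(=O)=O)cc1C(=O)N=C(N)N`: compound 1 gives 130 nM
- compound 2, `CSc1cc(C)c(C(=O)N=C(N)N)cc1S(C)(=O)=O`: compound 2 gives 6 nM
- compound 3, `Cc1cc(Sc2ccc(Cl)cc2)c(S(C)(=O)=O)cc1C(=O)N=C(N)N`: compound 3 gives 19 nM

Compound 3 stands second highest of the three numbers in this assay. Its nearest neighbour is compound 2, with a 3.2-fold higher number from compound 2 to compound 3 (0.50 log units; beyond the scatter); the furthest is compound 1, with a 6.8-fold lower number from compound 1 to compound 3 (0.84 log units; beyond the scatter). The largest movement in the set is a 22-fold lower number from compound 1 to compound 2 (1.34 log units; beyond the scatter).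

Compound 4, `Cc1cc(Oc2ccccc2Cl)c(S(C)(=O)=O)cc1C(=O)N=C(N)N`, is not yet measured. The change from compound 3 is 2-chlorophenoxy in place of (4-chlorophenyl)sulfanyl on an aromatic carbon. Among the measured compounds shown here, none of the measured steps covers this exact exchange. The steps from compound 1 show that replacing the 3,5-dichlorophenyl with a sulfur-linked group lowers the number, and the step from compound 2 to compound 3 shows that enlarging the group on the sulfur from methyl to 4-chlorophenyl raises it modestly. Compound 4 keeps a one-atom link to a chlorinated phenyl ring, so on these data a step of about the scatter or only modestly beyond it is expected in this assay, with no clear direction. The estimate for compound 4 in this assay is 20 nM, between 6 nM and 65 nM, which would mean a 1.1-fold higher number from compound 3 to compound 4 (0.02 log units; within the scatter).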

Compound 4, half-maximal inhibitory concentration: 14 nM
For compound 4 the middle estimate is 1.4-fold (0.15 log units) above the measured one, and the stated range covers the measured number.
By their numbers in this assay, from the lowest: compound 2; then compounds 4 and 3 (each within the scatter of the next); then compound 1.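

At this position, ortho to a methylsulfonyl group, 2-chlorophenoxy and (4-chlorophenyl)sulfanyl cannot be told apart in this assay (a 1.4-fold lower number from compound 3 to compound 4 (0.13 log units; within the scatter)), so an oxygen-linked chlorinated phenyl ring is accommodated here as well as the sulfur-linked one. Compound 4 also keeps the gain over the directly attached 3,5-dichlorophenyl of compound 1 (a 9.3-fold lower number from compound 1 to compound 4 (0.97 log units; beyond the scatter)) and, like compound 3, still falls short of the small methylsulfanyl group of compound 2 (a 2.3-fold higher number from compound 2 to compound 4 (0.37 log units; beyond the scatter)), so within these four compounds both aryl ethers and thioethers sit on the same side of that gap. No measurement among these compounds gives a reason for any of these steps.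

The exchange from compound 3 to compound 4 alters the linking atom and the chlorine location together, so the two contributions remain unseparated and could be offsetting each other. On these data alone, how an amine or a carboxylic acid at this aromatic carbon would read in this assay also stays open, as does whether any larger group linked through oxygen can match the methylsulfanyl of compound 2.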